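Removing a fluoro from a potent sulfonamide agonist

The compounds below may be only part of what the source reports. "The series", "measured", "known", "first", "only" and "open" are said of these compounds alone.

Measured compounds:
Compound 1, `C[C@@H]1CN(c2cccc(NS(=O)(=O)c3ccc(-c4ccccn4)s3)c2)C[C@H](C)N1`: 39.8 nM
Compound 2, `C[C@@H]1CN(c2ccc(F)c(NS(=O)(=O)c3ccc(-c4ccccn4)s3)c2)C[C@H](C)N1`: 100 nM
Compound 3, `COc1ccc(F)c(-c2ccc(S(=O)(=O)Nc3cc(N4C[C@@H](C)N[C@@H](C)C4)ccc3OC)cc2)c1`: 0.398 nM

The three compounds were tested in a functional assay for agonist activity at growth hormone secretagogue receptor type 1 (Homo sapiens), read by FLIPR; a lower number here means that less compound is needed, a higher number that more compound is needed for the effect. Compound 3 gives by far the lowest number; its difference from compound 2 is not broken down here, as the two cores differ in more than one place. Between compound 2 and compound 1 one change is made, (hydrogen in place of fluoro on an aromatic carbon), and it yields a 2.5-fold lower number from compound 2 to compound 1 (0.40 log units; beyond the scatter). Compound 4, `COc1cccc(-c2ccc(S(=O)(=O)Nc3cc(N4C[C@@H](C)N[C@@H](C)C4)ccc3OC)cc2)c1`, is not yet measured; it arises from compound 3 by hydrogen in place of fluoro on an aromatic carbon. This is the same kind of change as that from compound 2 to compound 1, though the place differs: in compound 1 it lies para to a 3,5-dimethylpiperazin-1-yl group, in compound 4 para to a methoxy group. Resting on the step from compound 2 to compound 1 and on the value of compound 3, a step of a 1.3-fold lower number from compound 3 to compound 4 (0.12 log units; within the scatter) is expected. Compound 4 is therefore estimated at 0.3 nM, with a range from 0.1 nM to 1 nM.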

Compound 4, half-maximal effective concentration: 2 nM
Beside the measured number, compound 4's estimate is 6.7-fold (0.82 log units) below it; measured number outside the range, above it.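

In this assay, hydrogen in place of the fluoro of the 2-fluoro-5-methoxyphenyl group gives a 5.0-fold higher number from compound 3 to compound 4 (0.70 log units; beyond the scatter). The same change therefore does not carry over from one core to the other in this series, as the two steps run in opposite directions: the same change on two cores in this assay, a 2.5-fold lower number (0.40 log units; beyond the scatter) from compound 2 to compound 1 and a 5.0-fold higher number (0.70 log units; beyond the scatter) from compound 3 to compound 4, 13-fold (1.10 log units) apart, beyond the scatter of two such steps This rests on a single pair for each core, with the change at a different place in each, so it shows that the earlier step cannot be transferred here, but not whether the core or the place accounts for the gap.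

As far as these compounds go, whether a chloro or a methyl on that aromatic carbon would match the fluoro remains open. So does the outcome of the change with an amine or a nitrile in place of the methoxy group.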